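This account rests on a few compounds, and the source may have more. Where it says the series, first, only, none or still open, it means among the compounds named here.

Compound 1, `CCOc1cc2[nH]c(Cc3nn(CC(=O)O)c(=O)c4ccccc34)nc2cc1Cl`: in a functional assay on CHO cells for antagonist activity at sphingosine 1-phosphate receptor 2 (Homo sapiens), read by GTPgammaS binding (a higher number here means a weaker inhibitor, a lower number a stronger inhibitor), compound 1 gives 109 nM.
Compound 2, `COC(C(=O)O)c1nn(Cc2cn3cc(OCC4CC4)c(Cl)cc3n2)c2ccccc2c1=O`: in this assay compound 2 gives 58 nM.
Compound 3, `O=C(O)Cc1nn(Cc2cn3cc(OCC4CC4)c(Cl)cc3n2)c2ccccc2c1=O`: in this assay compound 3 gives 30 nM.

Compound 3 has the lowest of the three numbers. Its nearest neighbour is compound 2, and the step of a 1.9-fold lower number from compound 2 to compound 3 (0.29 log units; within the scatter) lies within the scatter, so the two cannot be ranked against each other. Compound 1, which differs from compound 3 in more than one place, gives a higher number, and that gap lies beyond the scatter.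

Compound 4, `CCC(C(=O)O)c1nn(Cc2cn3cc(OCC4CC4)c(Cl)cc3n2)c2ccccc2c1=O`, has not yet been measured. It differs from compound 3 by ethyl in place of hydrogen on a saturated chain carbon bound to an aromatic carbon and a carbonyl carbon. Going by the values given here, only one measured step bears on this position: a 1.9-fold lower number from compound 2 to compound 3 (0.29 log units; within the scatter), where a methoxy group at the same saturated chain carbon was exchanged for hydrogen with a change within the scatter. That single step suggests a substituent at this carbon makes little difference to the number in this assay, though an ethyl group has not been tried and a single step is a thin basis.

The step of a 1.3-fold higher number from compound 3 to compound 4 (0.12 log units; within the scatter) is therefore expected to stay within the scatter. Compound 4 is estimated to give 40 nM, with a range from 15 nM to 120 nM.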

Compound 4, half-maximal inhibitory concentration: 43 nM
Compound 4: the middle estimate sits 1.1-fold (0.03 log units) below what was measured; measured number inside the range.
By their numbers in this assay, from the lowest: compounds 3, 4, 2 and 1 (each within the scatter of the next, the first and the last beyond it).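

Placing an ethyl group on the saturated chain carbon bound to an aromatic carbon and a carbonyl carbon gives a 1.4-fold higher number from compound 3 to compound 4 (0.16 log units; within the scatter) in this assay and so extends the earlier picture: until now this carbon had carried only hydrogen and methoxy, and a substituent built from carbon alone also leaves the number within the scatter. The direct exchange of methoxy for ethyl gives a 1.3-fold lower number from compound 2 to compound 4 (0.13 log units; within the scatter) and adds a further comparison, so hydrogen, methoxy and ethyl at this carbon, in these three compounds, cannot be told apart in this measurement. Nothing in the information available explains why these three groups cannot be separated.

Three small groups do not show how much this carbon will accept, and a longer chain such as butyl, a phenyl ring or an amine could give a quite different number. Also open, as far as these compounds go, is whether the two mirror-image forms of compound 4, which has two different carbon substituents on this carbon, would give the same number.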